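This account rests on a few compounds, and the source may have more. Where it says the series, first, only, none or still open, it means among the compounds named here.

Compound 1 `Cc1cc(C)c(-c2nc(CN3CCC(C(=O)NCCCN4C[C@H](C)C[C@H](C)C4)CC3)c(C)o2)c(C)c1` has no result in a physicochemical assay for permeability, using PAMPA; on this read-out lower numbers stand for lower permeability and higher numbers for higher permeability: its entry there reads "not determined" (no result reported), so compound 1 stands nowhere on the numbers shown and offers no starting point of its own. Two related compounds do carry numbers. Compound 2 `CC[C@@H]1C[C@H](CC)CN(CCCNC(=O)C2CCN(Cc3nc(-c4ccccc4C)oc3C)CC2)C1` gives 1270 10^-6 cm/s in this assay, and compound 3 `Cc1ccccc1-c1nc(CN2CCC(C(=O)NCCCN3CCC(C(C)C)CC3)CC2)c(C)o1` gives 396 10^-6 cm/s in this assay. Within the data shown here, the one step between measured compounds, a 3.2-fold lower number from compound 2 to compound 3 (0.51 log units; beyond the scatter), concerns 4-isopropylpiperidin-1-yl in place of 3,5-diethylpiperidin-1-yl on a saturated chain carbon, three bonds along the chain from an amide-type nitrogen, a place untouched by the change now considered.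

Compound 4 `Cc1cccc(C)c1-c1nc(CN2CCC(C(=O)NCCCN3C[C@H](C)C[C@H](C)C3)CC2)c(C)o1` differs from compound 1 in one place: hydrogen in place of methyl on an aromatic carbon. The 2,4,6-trimethylphenyl becomes 2,6-dimethylphenyl. Among the measured compounds shown here, no measured step touches this part of the shared core, so no measured step bears on it, and the size of the step in this assay cannot be read from the data; the expectation is a change within the scatter or a small one in either direction. What remains is the range spanned by compound 2 and compound 3, which share much of their structure with compound 4. On that basis the value expected for compound 4 in this assay is 600 10^-6 cm/s, within a range from 250 10^-6 cm/s to 1500 10^-6 cm/s.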

Compound 4, apparent permeability: 254 10^-6 cm/s
Beside the measured number, compound 4's estimate is 2.4-fold (0.37 log units) above it; measured number inside the range.
By their numbers in this assay, from the lowest: compounds 4 and 3 (each within the scatter of the next); then compound 2.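

Set beside compound 4 in this assay compound 1 offers no number, and compound 2 and compound 3 each differ from compound 4 in more than one place, so no new step can be read. Still open, on these data alone, is what going from 2,4,6-trimethylphenyl to 2,6-dimethylphenyl does to permeability. Nothing shown explains the value of compound 4.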